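The source may hold more compounds than are shown below. What is called first, only, known or untested is meant among the compounds shown, and "the series" means these compounds.

Measured compounds in a physicochemical assay for lipophilicity, measured as octanol-water partition, at pH 7.4; on this read-out higher numbers stand for higher lipophilicity and lower numbers for lower lipophilicity:
- compound 1, `Clc1ccc(NC2=NCCC3(CCCCC3)S2)cc1`, gives 2.5
- compound 2, `CC(C)c1ccc(NC2=NCCC3(CCCCC3)S2)cc1`, gives 1.57
- compound 3, `Brc1ccc(NC2=NCCC3(CCCCC3)S2)cc1`, gives 2.53

Compound 3 has the highest of the three numbers, though the gap to compound 1 is within the scatter, and only compound 2 lies clearly lower. Compound 4, `COc1ccc(NC2=NCCC3(CCCCC3)S2)cc1`, is not yet measured; it differs from compound 3 by methoxy in place of bromo on an aromatic carbon. Within the data shown here, no measured step brings in a methoxy group. The step of a number 0.03 log units higher from compound 1 to compound 3 (within the scatter) shows that exchanging one halogen for another at this aromatic carbon changes little, while a number 0.96 log units higher from compound 2 to compound 3 (beyond the scatter) shows that a different kind of group there can move this assay by a modest amount. A modest drop is therefore expected for compound 4, a number 0.88 log units lower from compound 3 to compound 4 (beyond the scatter), giving an estimated value of 1.65 with a range from 1.2 to 2.1.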

Compound 4, distribution coefficient: 0.8
Beside the measured number, compound 4's estimate is 0.85 log units above it; the whole stated range lies above it.
By their numbers in this assay, from the lowest: compound 4; then compound 2; then compounds 1 and 3 (each within the scatter of the next).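

In this assay methoxy at this aromatic carbon, para to a large group, gives the lowest number of the four compounds, with a number 1.73 log units lower from compound 3 to compound 4 (beyond the scatter) and a number 1.70 log units lower from compound 1 to compound 4 (beyond the scatter) and also a number 0.77 log units lower from compound 2 to compound 4 (beyond the scatter). Among these compounds, this position can therefore move the number further than the earlier compounds showed, and both non-halogen groups lie clearly below the two halogens. Nothing available explains why methoxy falls this far. Still open, on these data alone, is where an amine or a carboxylic acid at this carbon would fall, and whether a longer chain such as ethoxy would stay near methoxy.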